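Nitro for Methyl on a Shared Oxindole-Type Core

A few compounds are considered here, and "the series" means these few. Any claim that something is new, unique, unknown or untested is made for them only; others in the source may bear on it.

The measured compounds are:
compound 1, `CC(C)n1c(/C=C2/C(=O)Nc3ccc(F)cc32)nc2ccccc21`, 25800 nM in a functional assay on 4T1 cells (Homo sapiens) for cytotoxicity, read by MTT assay, with a stated time of 48 h; a higher number here means a weaker inhibitor, a lower number a stronger inhibitor;
compound 2, `CCn1c(/C=C2/C(=O)Nc3ccc(C)cc32)nc2ccccc21`, 39400 nM in this assay.

Going by the values given here, compound 2 has the highest of the two numbers so far in this assay, yet its nearest neighbour is compound 1, whose number is lower by an amount that lies within the scatter of repeated measurements. The two therefore cannot be ordered against each other on these data.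

Compound 3, `CCn1c(/C=C2/C(=O)Nc3ccc([N+](=O)[O-])cc32)nc2ccccc21`, has not yet been measured. It differs from compound 2 in one place: nitro in place of methyl on an aromatic carbon. The change is carried out on an aromatic carbon of a six-membered aromatic ring of carbon only, part of a fused or bridged system of two rings, meta to a fused ring and para to a fused ring.

Among the compounds with values here, no measured pair records the effect of this particular exchange, so the expectation rests only on compound 2 and compound 1. The step from compound 2 to compound 3 in this assay is expected to be small, a 1.3-fold lower number from compound 2 to compound 3 (0.12 log units; within the scatter), not clearly beyond the scatter in either direction. The estimate for compound 3 in this assay is 30000 nM, with a range from 10000 nM to 100000 nM.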

Compound 3, half-maximal inhibitory concentration: > 50000 nM
Compound 3: no number, only a limit (the forecaster's own chance of this, stated with the estimate: 10%); middle value at least 1.6-fold (0.22 log units) from the limit.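

Compound 3 gives > 50000 nM in this assay, and this is a limit of the assay, not a number. Placing nitro in place of methyl on this aromatic carbon, meta to a fused ring and para to a fused ring, gives an at least 1.2-fold higher number from compound 2 to compound 3 (0.10 log units; that floor lies within the scatter), so this is the first reading of a change at this position, and it shows no sign that nitro here brings a lower number than methyl, though the printed floor of the step does not separate the pair beyond the scatter. The true size of the step stays unread, and the change may be small or much larger, because the reading of compound 3 ends at a limit: the limit of > 50000 nM in this assay, at which 1 of the 3 values shown sits.

The compounds shown leave open how far compound 3 actually lies from compound 2, and so whether nitro at this position truly weakens the compound or merely matches methyl. They also leave open what an amine or a carboxylic acid on the same aromatic carbon of the shared core would do in this assay.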